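Swapping one aryl group in a series stuck at a limit

The compounds below may be only part of what the source reports. "The series", "measured", "known", "first", "only" and "open" are said of these compounds alone.

Compound 1 `C=C[C@@](C)(/C=C/c1ccc(OC)cc1)CCC=C(C)C`: > 36600 nM, a limit
Compound 2 `C=C[C@@](C)(/C=C/c1ccc(OS(=O)(=O)C(F)(F)F)cc1)CCC=C(C)C`: > 36600 nM, a limit
Compound 3 `C=C[C@@](C)(/C=C/c1ccc(Nc2cc(F)c(F)c(F)c2)cc1)CCC=C(C)C`: > 36600 nM, a limit

All three compounds were tested in a functional assay on SEM cells (Homo sapiens) for cytotoxicity, with a stated time of 72 h (on this read-out lower numbers stand for an effect already at smaller amounts and higher numbers for an effect only at larger amounts of compound), and the result is uniform: the limit of > 36600 nM in this assay, at which 3 of the 3 values shown sit. Compound 3 therefore offers only a limit, > 36600 nM, and not a true number to start from.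

Compound 4 `C=C[C@@](C)(/C=C/c1ccc(Nc2ccc(Cl)cc2)cc1)CCC=C(C)C` differs from compound 3 in one place, with 4-chlorophenyl in place of 3,4,5-trifluorophenyl on a nitrogen on an aromatic ring.

Within the data shown here, the only step between measured neighbours is a step that the two limits leave unreadable from compound 1 to compound 2. It concerns a different group and gives no size to carry over. Among the measured compounds shown here, the sole guide is thus the shared ceiling, (the limit of > 36600 nM in this assay, at which 3 of the 3 values shown sit), so no change in either direction is expected in this assay, and another limit is the likeliest outcome.

The estimated step is a number no higher from compound 3 to compound 4 (the limit leaves the size open), which means none beyond the usual scatter. For compound 4 the expected value is 36600 nM, with an estimated range from 15000 nM to 60000 nM.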

Compound 4, half-maximal effective concentration: > 36600 nM
Compound 4 was reported as a limit (the forecaster's own chance of this, stated with the estimate: 75%); the middle value lies on the limit itself.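

Compound 4 stays a limit, as do compounds 1, 2 and 3, so no step among these four compounds can be read: the limit of > 36600 nM in this assay, at which 4 of the 4 values shown sit.

What the compounds shown leave open is whether any of them has a true value in this assay, and how large any difference between them would be.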